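Replacing the Phthalimide of Compound 1 with a 4-Ethylbenzamide

The source may hold more compounds than are shown below. What is called first, only, known or untested is meant among the compounds shown, and "the series" means these compounds.

Measured compounds:
- compound 1 `CN1[C@@H]2c3[nH]c4ccccc4c3C[C@H]1[C@H](C#N)N1[C@@H](CN3C(=O)c4ccccc4C3=O)c3[nH]c4ccccc4c3C[C@@H]21`: 80 nM
- compound 2 `CN1[C@@H]2c3[nH]c4ccccc4c3C[C@H]1[C@H](C#N)N1[C@@H](CNC(=O)c3cccc(C(F)(F)F)c3)c3[nH]c4ccccc4c3C[C@@H]21`: 140 nM
- compound 3 `CN1[C@@H]2c3[nH]c4ccccc4c3C[C@H]1[C@H](C#N)N1[C@@H](CNC(=O)c3ccc(F)cc3)c3[nH]c4ccccc4c3C[C@@H]21`: 1370 nM

In a functional assay on HT-29 cells (Homo sapiens) for cytotoxicity, read by MTT assay, with a stated time of 72 h (on this read-out lower numbers stand for stronger inhibition and higher numbers for weaker inhibition), compound 1 gives the lowest number of the three; compound 2 lies within the scatter of it, while compound 3 is clearly weaker, as a 17-fold higher number from compound 1 to compound 3 (1.23 log units; beyond the scatter) shows. Compound 4 `CCc1ccc(C(=O)NC[C@H]2c3[nH]c4ccccc4c3C[C@H]3[C@H]4c5[nH]c6ccccc6c5C[C@@H]([C@H](C#N)N23)N4C)cc1` differs from compound 1 by a group of 11 heavy atoms (9 carbon, 1 nitrogen, 1 oxygen; one six-membered aromatic ring of carbon only) in place of a group of 11 heavy atoms (8 carbon, 1 nitrogen, 2 oxygen; one five-membered non-aromatic ring with 1 hetero atom, one six-membered aromatic ring of carbon only), on a saturated chain carbon bound to a saturated ring carbon. Within the data shown here, two measured steps bear on this change: a 17-fold higher number from compound 1 to compound 3 (1.23 log units; beyond the scatter) shows that swapping the same leaving group for an amide-linked aromatic ring cost potency, and a 9.8-fold higher number from compound 2 to compound 3 (0.99 log units; beyond the scatter) shows that the substituent on that ring can move the number. Compound 4 carries a ((4-ethylphenyl)carbonyl)amino group, so a loss beyond the scatter is expected, though likely smaller than for compound 3, as a 7.5-fold higher number from compound 1 to compound 4 (0.88 log units; beyond the scatter) expresses. Compound 4 is therefore estimated at 600 nM, between 150 nM and 2500 nM.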

Compound 4, half-maximal inhibitory concentration: 3560 nM
Compound 4: middle estimate off by 5.9-fold (0.77 log units), on the low side, and the stated range ends below it.
By their numbers in this assay, from the lowest: compounds 1 and 2 (each within the scatter of the next); then compound 3; then compound 4.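

The ((4-ethylphenyl)carbonyl)amino group moves the number well away from that of the phthalimide of compound 1 (a 45-fold higher number from compound 1 to compound 4 (1.65 log units; beyond the scatter)). Ethyl does worse than fluoro on the aromatic carbon (a 2.6-fold higher number from compound 3 to compound 4 (0.41 log units; beyond the scatter)), and 4-ethylphenyl does much worse than 3-(trifluoromethyl)phenyl on the carbonyl carbon (a 25-fold higher number from compound 2 to compound 4 (1.41 log units; beyond the scatter)). Replacing the phthalimide with an amide therefore does not set the outcome alone: compound 2 stays within the scatter of compound 1, while compound 3 and compound 4 do not.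

No measurement here explains why these substituents differ. As far as these compounds go, whether a methoxy group or a carboxylic acid on the same aromatic ring would give a lower or a higher number remains open.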